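A few compounds are considered here, and "the series" means these few. Any claim that something is new, unique, unknown or untested is made for them only; others in the source may bear on it.

Compound 1 `CS/C(=N\C(=O)c1sccc1Cl)NC(=O)c1sccc1Cl`: in a functional assay on HepG2 cells (Homo sapiens) for cytotoxicity, read by MTT assay, with a stated time of 72 h (on this read-out higher numbers stand for weaker inhibition of growth and lower numbers for stronger inhibition of growth), compound 1 gives > 100000 nM, which is a limit of the assay and not a number.
Compound 2 `C[Se]/C(=N\C(=O)c1ccco1)NC(=O)c1ccco1`: in this assay compound 2 gives 8660 nM.
Compound 3 `CS/C(=N\C(=O)c1cc2ccccc2s1)NC(=O)c1cc2ccccc2s1`: in this assay compound 3 gives 53000 nM.

Compound 2 holds the lowest of the two numbers shown; compound 3 is the nearest, and it sits beyond the scatter above compound 2. Compound 4 `CS/C(=N\C(=O)c1ccco1)NC(=O)c1ccco1` has not yet been measured in this assay. It differs from compound 2 by a group of 2 heavy atoms (1 carbon, 1 sulfur; no ring) in place of a group of 2 heavy atoms (1 carbon, 1 selenium; no ring), on a carbon with a double bond to nitrogen. Among the compounds with values here, no pair of measured compounds here differs in a single place, so the size of this step cannot be read from the data. The two methylsulfanyl compounds shown, compound 1 and compound 3, both stand at higher numbers than compound 2, though each also carries other ring systems. A modest step toward a higher number is therefore expected, a 2.9-fold higher number from compound 2 to compound 4 (0.46 log units; beyond the scatter). Compound 4 is estimated at about 25000 nM, with a range from 8000 nM to 80000 nM.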

Compound 4, concentration for total growth inhibition: > 100000 nM
Compound 4 gave a limit, no number (the forecaster's own chance of this, stated with the estimate: 15%); at least 4.0-fold (0.60 log units) between middle value and limit.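

Within the data shown here, on the carbon with a double bond to nitrogen, methylsulfanyl in place of the carbon and selenium group gives an at least 11-fold higher number from compound 2 to compound 4 (1.06 log units; beyond the scatter) in this assay, the first step here that changes one place alone. Compound 1 and compound 3 could not show this, as each also carries other ring systems. The true size of the step remains unknown because compound 4 gives a limit and not a number: the limit of > 100000 nM in this assay, at which 2 of the 4 values shown sit.

On these data alone, whether selenium has the same effect on the cores of compound 1 and compound 3 remains open. So does what an amine or a longer chain would give on this carbon.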